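Swapping an ether tail for a sulfone on a charged oxime

This account rests on a few compounds, and the source may have more. Where it says the series, first, only, none or still open, it means among the compounds named here.

Compound 1 `COC(C)CCOCn1cc[n+](C)c1/C=N/O` and compound 2 `C[n+]1ccn(CCCCOC(=O)c2ccccc2O)c1/C=N/O` share a charged core carrying an oxime. Among the measured compounds shown here, in a physicochemical assay for lipophilicity (on this read-out lower numbers stand for lower lipophilicity and higher numbers for higher lipophilicity), compound 1 gives -2.22, the lower of the two numbers known here. Compound 2 gives -0.56 in this assay, and the gap to compound 1 lies beyond the usual scatter of this kind of measurement, so compound 2 is clearly the more lipophilic of the pair.

Compound 3 `C[n+]1ccn(COCCS(C)(=O)=O)c1/C=N/O` has not yet been measured in this assay. It differs from compound 1 in one place: methylsulfonyl in place of 1-methoxyethyl on a saturated chain carbon, two bonds along the chain from an oxygen on a saturated carbon. For the measured compounds named here, no pair of measured compounds here differs in only one place, so nothing measured shows how large such a change is in this assay. The step from compound 1 to compound 3 is expected to be a modest fall, a number 0.58 log units lower from compound 1 to compound 3 (beyond the scatter), likely beyond the scatter. Compound 3 is therefore estimated at -2.8, within a range from -3.5 to -2.1.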

Compound 3, distribution coefficient: < -3.3
Compound 3: a limit, no number; the forecaster's own chance of this, stated with the estimate: 15%; middle value at least 0.50 log units away from the limit.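

Among the compounds shown here, until this result, no two measured compounds differed in only one place, so the size of any single change at this saturated chain carbon was unknown. In this assay, putting methylsulfonyl in place of 1-methoxyethyl gives a number at least 1.08 log units lower from compound 1 to compound 3 (beyond the scatter), which shows that a swap of two tails with the same count of heavy atoms can move this read-out by a large amount at this position. The result for compound 3 is a limit and not a number: the limit of < -3.3 in this assay, at which 1 of the 3 values shown sits.

For the compounds shown here, with only one change measured at this position, it remains open whether other replacements for 1-methoxyethyl would move the read-out as far. An amine, a carboxylic acid or a simple methyl group at the same carbon, each compared directly with compound 1, would help to show how much of the step belongs to methylsulfonyl itself.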